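Moving the fluorine and dropping the trifluoromethoxy group

The source may report more compounds than this note shows. Statements on the series, on what has been measured and on what is new or still open speak of the compounds shown alone.

Compounds measured so far:
compound 1, `Cc1cnc(Nc2ccc(C(=O)Nc3c(C)cccc3C)cc2)nc1-c1cccc(OC(F)(F)F)c1`, 1.2 nM
compound 2, `Cc1cnc(Nc2ccc(C(=O)Nc3c(C)cccc3C)cc2)nc1-c1ccc(OC(F)(F)F)c(F)c1`, 159 nM

For the measured compounds named here, in an assay on NIH3T3 cells for inhibition of Sonic hedgehog protein (Mus musculus), read by a luciferase reporter, with a stated time of 48 h (a higher number here means a weaker inhibitor, a lower number a stronger inhibitor), compound 2 stands highest of the two numbers; its nearest neighbour is compound 1, and the only measured step, a 130-fold higher number from compound 1 to compound 2 (2.12 log units; beyond the scatter), is large. Compound 3, `Cc1cnc(Nc2ccc(C(=O)Nc3c(C)cccc3C)cc2)nc1-c1ccc(F)cc1`, has not been measured; it differs from compound 2 by 4-fluorophenyl in place of 3-fluoro-4-(trifluoromethoxy)phenyl on an aromatic carbon. Going by the values given here, no measured step bears directly on this change, yet the step from compound 1 to compound 2 shows that the pattern on this ring can swing the number widely. The step of a 5.3-fold lower number from compound 2 to compound 3 (0.72 log units; beyond the scatter) is therefore expected to be downward but very uncertain. Compound 3 is estimated at 30 nM, within 3 nM to 300 nM.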

Compound 3, half-maximal inhibitory concentration: 2.2 nM
The estimate for compound 3 lay 14-fold (1.13 log units) above the measured number, and the stated range ends above it.
By their numbers in this assay, from the lowest: compounds 1 and 3 (each within the scatter of the next); then compound 2.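

The step of a 72-fold lower number from compound 2 to compound 3 (1.86 log units; beyond the scatter) in this assay shows that this position reaches the low range with 4-fluorophenyl, with no trifluoromethoxy group present. The step of a 1.8-fold higher number from compound 1 to compound 3 (0.26 log units; within the scatter) lies within the scatter, so 4-fluorophenyl and 3-(trifluoromethoxy)phenyl cannot be told apart here, and the high number belongs to the 3-fluoro-4-(trifluoromethoxy)phenyl of compound 2 alone. Nothing available explains the gap between these rings. The compounds shown leave open whether 4-(trifluoromethoxy)phenyl alone would give a high number, or whether the fluorine of 4-fluorophenyl matters at all compared with plain phenyl, 4-chlorophenyl or 4-aminophenyl.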